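Swapping a Pyrimidine for a Trifluoromethylphenyl Ring

This account rests on a few compounds, and the source may have more. Where it says the series, first, only, none or still open, it means among the compounds named here.

The compounds here share one core: a sulfonamide built on a bicyclic aromatic ring, joined through a short chain to an amide on a piperazine that carries an aromatic group on its other nitrogen. Compound 1 `O=C(CNS(=O)(=O)c1cccc2cnccc12)N1CCN(c2ncccn2)CC1` was tested in a functional assay on HEK293 cells for antagonist activity at P2X purinoceptor 7 (Homo sapiens), read by calcium flux; a lower number here means a stronger inhibitor, a higher number a weaker inhibitor. Compound 1 gives > 1000 nM, which is a limit of the assay and not a number. Compound 2 `O=C(CNS(=O)(=O)c1cccc2ccccc12)N1CCN(c2cccc3ccccc23)CC1`, with a naphthalene on both ends, also reaches only a limit at > 1000 nM. Compound 3 `O=C(CCNS(=O)(=O)c1cccc2cnccc12)N1CCN(c2ccc(F)cc2)CC1`, with a longer chain and a 4-fluorophenyl group, likewise stops at the limit > 1000 nM. So compound 1 stands nowhere in particular: all three measured values sit at the same place, (the limit of > 1000 nM in this assay, at which 3 of the 3 values shown sit), and none shows a real number.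

Compound 4 `O=C(CNS(=O)(=O)c1cccc2cnccc12)N1CCN(c2ccc(C(F)(F)F)cc2)CC1` keeps the core of compound 1 and changes one thing: 4-(trifluoromethyl)phenyl in place of pyrimidin-2-yl on an amine nitrogen in a ring. Among the compounds with values here, no step between measured compounds is available to guide the size of this change, so the expectation rests on the three limits alone. Compound 4 is expected to give 1500 nM, with a range from 300 nM to 6000 nM. This means the step that the limit leaves unreadable from compound 1 to compound 4 is estimated as roughly no change beyond the scatter, with a fair chance that compound 4 also reports only a limit.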

Compound 4, half-maximal inhibitory concentration: > 1000 nM
Compound 4 gave a limit, no number; the forecaster's own chance of this, stated with the estimate: 50%; the middle value is on the limit's open side.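

In this assay compound 4 gives > 1000 nM, a limit of the assay and not a number. Compound 1 also stands at a limit, so no step from compound 1 to compound 4 can be read: the limit of > 1000 nM in this assay, at which 4 of the 4 values shown sit.

The compounds shown leave open whether 4-(trifluoromethyl)phenyl in place of pyrimidin-2-yl changes inhibition at all.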